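Nitro for cyano on two anilide cores

A few compounds are considered here, and "the series" means these few. Any claim that something is new, unique, unknown or untested is made for them only; others in the source may bear on it.

Compound 1 `CC(O)(COc1cc(C(F)(F)F)cc(C(F)(F)F)c1)C(=O)Nc1ccc(C#N)cc1C(F)(F)F` and compound 2 `CC(O)(COc1cc(C(F)(F)F)cc(C(F)(F)F)c1)C(=O)Nc1ccc([N+](=O)[O-])cc1C(F)(F)F` share one core and differ at a single point: nitro in place of cyano on an aromatic carbon. In a functional assay on DU-145 cells (Homo sapiens) for antiproliferative activity, read by fluorescence and propidium iodide staining, with a stated time of 96 h (a higher number here means a weaker inhibitor, a lower number a stronger inhibitor), compound 1 gives 8050 nM, and compound 2 gives 11600 nM; the step of a 1.4-fold higher number from compound 1 to compound 2 (0.16 log units; within the scatter) stays within the scatter, so the two values are read as equal.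

Compound 3 `CC(O)(CS(=O)(=O)c1cc(C(F)(F)F)cc(C(F)(F)F)c1)C(=O)Nc1ccc(C#N)cc1C(F)(F)F` carries a different core; the difference between the two cores is not broken down here. In this assay compound 3 returned "nd(insoluble)" (no result reported), so no number stands for it.

Compound 4 `CC(O)(CS(=O)(=O)c1cc(C(F)(F)F)cc(C(F)(F)F)c1)C(=O)Nc1ccc([N+](=O)[O-])cc1C(F)(F)F` repeats the same kind of change on the core of compound 3: nitro in place of cyano on an aromatic carbon. The place lines of the two changes read the same word for word. In this assay a step of about the size seen from compound 1 to compound 2 is expected for compound 3 to compound 4, because a 1.4-fold higher number from compound 1 to compound 2 (0.16 log units; within the scatter) sat within the scatter; the anchor is absent, since compound 3 gave no number.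

Compound 4 is therefore expected near 12000 nM in this assay, between 3000 nM and 50000 nM, with a real risk that no number is obtained.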

Compound 4, half-maximal inhibitory concentration: 3050 nM
Beside the measured number, compound 4's estimate is 3.9-fold (0.59 log units) above it; the measured number falls inside the stated range.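

No new step can be read between compound 3 and compound 4: in this assay compound 3 has no number, and compound 4 stands at 3050 nM without a partner. From the compounds shown here alone, what stays open is whether nitro for cyano on the core of compound 3 matches a 1.4-fold higher number from compound 1 to compound 2 (0.16 log units; within the scatter) on the core of compound 1. No measured evidence bears on this result.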